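This account rests on a few compounds, and the source may have more. Where it says the series, first, only, none or still open, it means among the compounds named here.

Measured compounds:
Compound 1, `CCc1nn(C)c2c1C(c1cccc(Br)c1)=NCCN2`: 1.25 mg/kg
Compound 2, `Cc1nn(C)c2c1C(c1cccc(F)c1)=NCCN2`: 2.5 mg/kg

Of the compounds shown here, two have been tested in a functional assay on the whole organism for positive allosteric modulation, with Rattus norvegicus as the target; on this read-out higher numbers stand for an effect only at larger amounts of compound and lower numbers for an effect already at smaller amounts. Compound 1, `CCc1nn(C)c2c1C(c1cccc(Br)c1)=NCCN2`, gives 1.25 mg/kg in this assay. Compound 2, `Cc1nn(C)c2c1C(c1cccc(F)c1)=NCCN2`, gives 2.5 mg/kg in this assay. Only these two numbers exist, and the difference between the reading of compound 2 and that of compound 1 lies within the usual scatter of repeated measurements, so neither stands apart from the other. For the measured compounds named here, no step between measured compounds that differ in one place is available.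

Compound 3, `CCc1nn(C)c2c1C(c1cccc(F)c1)=NCCN2`, has not yet been measured. Compared with compound 2 it carries the difference (methyl in place of hydrogen on a saturated chain carbon bound to an aromatic carbon). The data hold nothing that isolates this change on its own. From the two readings of compound 1 and compound 2, both within scatter of each other, compound 3 is expected to land close by, with a step of a 1.7-fold lower number from compound 2 to compound 3 (0.22 log units; within the scatter) that is not expected to exceed the scatter. Compound 3 is estimated at 1.5 mg/kg, in a range from 0.6 mg/kg to 3.5 mg/kg.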

Compound 3, minimum effective dose: 2.5 mg/kg
Estimate against measurement, compound 3: 1.7-fold (0.22 log units) below; measured number inside the range.
By their numbers in this assay, from the lowest: compounds 1, 2 and 3 (each within the scatter of the next).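

In this assay, methyl in place of hydrogen on a saturated chain carbon bound to an aromatic carbon, which amounts to methyl to ethyl, gives no change at the digits printed from compound 2 to compound 3 (within the scatter) and can now be read on its own, which compound 1 and compound 2 did not allow. Fluoro in place of bromo on an aromatic carbon can now be read alone as well and gives a 2.0-fold higher number from compound 1 to compound 3 (0.30 log units; within the scatter), so neither single change stands clear of the scatter in this whole-organism read-out. No evidence on the cause of these readings is available.

The compounds shown leave open whether a longer chain such as propyl, or an amine carried on that chain, would read the same in this assay. They also leave open how chloro or a nitrile would read in place of the fluoro on the aromatic carbon.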